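The compounds below may be only part of what the source reports. "The series", "measured", "known", "first", "only" and "open" are said of these compounds alone.

Of the compounds shown here, three have so far been tested in a functional assay on HT-29 cells (Homo sapiens) for inhibition, read by sulforhodamine B assay, with a stated time of 48 h; on this read-out lower numbers stand for stronger inhibition of growth and higher numbers for weaker inhibition of growth. Compound 1 (`c1cc(C2CCCCC2)ccc1NC1=NCCO1`) gives 12800 nM and compound 2 (`c1ccc(COc2ccc(NC3=NCCO3)cc2)cc1`) gives 10300 nM, two values within the usual scatter of each other. Compound 3 (`O=C(CCl)NC(=O)Nc1ccc(-c2ccccc2)cc1`) gives 2300 nM. That is the lowest number of the three, and its gap to each of the other two lies beyond the scatter, so compound 3 is the most potent of this small set.

Compound 4 (`Cc1ccc(NC(=O)NC(=O)CCl)cc1`) keeps everything in compound 3 except one group: methyl in place of phenyl on an aromatic carbon. In words, a methyl stands in place of a phenyl on an aromatic carbon, so a whole ring is removed from the structure. Going by the values given here, no pair of measured compounds differs in one place, so the data do not show directly what such a swap does. The expectation can rest only on compound 3 at 2300 nM and on the size of the change. A moderate loss of growth inhibition seems most likely, beyond the scatter but not large. The expected change is a 3.5-fold higher number from compound 3 to compound 4 (0.54 log units; beyond the scatter), towards a higher number. In this assay, compound 4 is estimated at 8000 nM, within an expected range of 2500 nM to 25000 nM.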

Compound 4, concentration for 50% growth inhibition: 10000 nM
Estimate against measurement, compound 4: 1.3-fold (0.10 log units) below, within the range that was stated.
By their numbers in this assay, from the lowest: compound 3; then compounds 4, 2 and 1 (each within the scatter of the next).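

Going by these compounds alone, the pair of compound 3 and compound 4 gives the first direct reading of a single change in this set. In this assay the swap of phenyl for methyl on the aromatic carbon, para to a group of 8 heavy atoms, brings a 4.3-fold higher number from compound 3 to compound 4 (0.64 log units; beyond the scatter) and so shows that growth inhibition responds to the group at this place, with the step modest but beyond the scatter. The phenyl, with its whole ring, goes with the lower number here, yet nothing available explains why the step has this size.

Within the data shown here, with only two groups seen at this position, it remains open whether the number follows the count of heavy atoms there or depends on an aromatic ring being present. On these data alone, an ethyl group, a methoxy group or a carboxylic acid at the same carbon would help to separate these readings, and the effect of the same swap on a different core also remains unknown.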